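The compounds below may be only part of what the source reports. "The series", "measured", "known", "first", "only" and "open" are said of these compounds alone.

In a functional assay on A549 cells (Homo sapiens) for cytotoxicity, read by XTT assay, with a stated time of 24 h (a lower number here means a stronger inhibitor, a higher number a weaker inhibitor), compound 1 `CN(C)c1ccc(/C=N/NC(=O)CSc2nnnn2C)cc1` gives 100000 nM. Compound 2 `Cn1nnnc1SCC(=O)N/N=C/c1cccc([N+](=O)[O-])c1` is the second of the two measured compounds. For compound 2 this assay reports only a limit, > 10000000 nM. That limit is where one of the two values shown sits (the limit of > 10000000 nM in this assay, at which 1 of the 2 values shown sits). Compound 3 `Cc1cccc(/C=N/NC(=O)CSc2nnnn2C)c1` differs from compound 2 by methyl in place of nitro on an aromatic carbon. Among the compounds with values here, no step between two measured compounds is known, so the size of this change cannot be read from a neighbouring pair, and compound 1 with compound 2 shows only that both act weakly. Only a weak effect in this assay is expected for compound 3, with 1000000 nM as the estimate and a range from 100000 nM to 10000000 nM. The step this estimate means, an at least 10-fold lower number from compound 2 to compound 3 (1.00 log units; beyond the scatter), is expected to point toward a stronger inhibitor than the limit of compound 2, though a further limit would not be surprising.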

Compound 3, half-maximal inhibitory concentration: 2000000 nM
Estimate against measurement, compound 3: 2.0-fold (0.30 log units) below; measured number inside the range.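

In this assay, within the data shown here, methyl in place of nitro on the aromatic carbon gives an at least 5.0-fold lower number from compound 2 to compound 3 (0.69 log units; beyond the scatter), the first step that can be read, and it shows that the group at this place can change the result. Compound 2 gives > 10000000 nM, which is a limit, so this step gives only the smallest size the change could have. Even so, compound 3 gives 2000000 nM, so the methyl compound remains a weak inhibitor.

With only nitro and methyl compared at this place, the step cannot separate the effect of removing one group from that of adding the other, and an amine or a chlorine on the same carbon would give further points of comparison. From the compounds shown here alone, whether methyl would behave the same on another carbon of the ring also remains open.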